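Aryl swap on the hydrazone carbon: compound 2 to compound 3

The compounds below may be only part of what the source reports. "The series", "measured", "known", "first", "only" and "open" are said of these compounds alone.

Compound 1 `CCCSc1nc(N/N=C/c2ccc([N+](=O)[O-])cc2)c2nnn(Cc3ccccc3)c2n1` and compound 2 `CCCSc1nc(N/N=C/c2c(O)ccc3ccccc23)c2nnn(Cc3ccccc3)c2n1` share one core and differ only in the aryl group on a carbon with a double bond to nitrogen. In a functional assay on ECa-109 cells (Homo sapiens) for antiproliferative activity, read by MTT assay, with a stated time of 72 h (a higher number here means a weaker inhibitor, a lower number a stronger inhibitor), compound 1 gives 6640 nM and compound 2 gives 9290 nM, the larger of the two numbers shown, a gap that is within the scatter: a 1.4-fold higher number from compound 1 to compound 2 (0.15 log units; within the scatter). Compound 3 `CCCSc1nc(N/N=C/c2ccc(Br)cc2)c2nnn(Cc3ccccc3)c2n1` carries 4-bromophenyl in place of 2-hydroxynaphthalen-1-yl on a carbon with a double bond to nitrogen. For the measured compounds named here, the one measured step, an exchange of aryl groups at this same place, stayed within the scatter, so the step to compound 3 is expected to be a 1.2-fold lower number from compound 2 to compound 3 (0.09 log units; within the scatter), nothing beyond the scatter. Compound 3 is therefore estimated at 7500 nM, between 3200 nM and 17000 nM.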

Compound 3, half-maximal inhibitory concentration: > 64000 nM
Compound 3: no number, only a limit; the forecaster's own chance of this, stated with the estimate: 5%; middle value at least 8.5-fold (0.93 log units) away from the limit.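

In this assay compound 3 gives no number, only a limit of the assay: the limit of > 64000 nM in this assay, at which 1 of the 3 values shown sits. The earlier exchange at this carbon with a double bond to nitrogen stayed within the scatter, but this one does not, showing that the aryl group here can matter: the steps are an at least 6.8-fold higher number from compound 2 to compound 3 (0.83 log units; beyond the scatter) and an at least 9.6-fold higher number from compound 1 to compound 3 (0.98 log units; beyond the scatter) at this one place. Their full size cannot be read past the limit.

The compounds shown leave open what a 4-aminophenyl or a 4-carboxyphenyl group would give at this place.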